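Notes on a cinnamate series at the bile acid receptor

This account rests on a few compounds, and the source may have more. Where it says the series, first, only, none or still open, it means among the compounds named here.

Measured in an assay on isolated protein with Bile acid receptor (Homo sapiens) as the target; a lower number here means that less compound is needed, a higher number that more compound is needed for the effect:
compound 1 `COC(=O)/C=C/c1cccc(N(Cc2ccc(-c3ccc(OC)cc3)cc2)C(=O)C2CCCCC2)c1` — 89 nM
compound 2 `COC(=O)/C=C/c1cccc(N(Cc2ccc(-c3ccc(C)cc3)cc2)C(=O)NC(C)C)c1` — 449 nM
compound 3 `CCOC/C=C/c1cccc(N(Cc2ccc(/C=C/C(=O)OC(C)(C)C)cc2)C(=O)C2CCCCC2)c1` — 220 nM

Compound 1 gives the lowest of the three numbers in this assay. Compound 3 comes nearest, and its gap to compound 1 is beyond the usual scatter; compound 2 is furthest, also beyond the scatter. No two of these compounds differ in a single place, so none of the gaps can be tied to one change.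

The next compound, compound 4 `COC(=O)/C=C/c1cccc(N(Cc2ccc(/C=C/c3ccc(F)cc3)cc2)C(=O)C2CCCCC2)c1`, differs from compound 1 in one place: 2-(4-fluorophenyl)ethenyl in place of 4-methoxyphenyl on an aromatic carbon. Compound 3 carries a double bond outside the aromatic rings in a comparable part of the molecule and sits above compound 1, but it also differs elsewhere, so it gives only a loose hint. Without a matched step the expectation rests on that hint alone. Compound 4 is expected to need somewhat more compound than compound 1, a step of a 1.8-fold higher number from compound 1 to compound 4 (0.25 log units; within the scatter) that may or may not clear the scatter. For compound 4 the estimate is 160 nM, in a range from 55 nM to 480 nM.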

Compound 4, half-maximal effective concentration: 185 nM
Compound 4: the middle estimate sits 1.2-fold (0.06 log units) below what was measured; measured number inside the range.
By their numbers in this assay, from the lowest: compound 1; then compounds 4 and 3 (each within the scatter of the next); then compound 2.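

Within the data shown here, on an aromatic carbon para to a large group, 2-(4-fluorophenyl)ethenyl in place of 4-methoxyphenyl gives, in this assay, a 2.1-fold higher number from compound 1 to compound 4 (0.32 log units; beyond the scatter), the first step that can be tied to a single place. The position therefore accepts a substituent with a double bond outside the aromatic rings at a modest cost, which compound 3 could only hint at since it also differs elsewhere. The change is nonetheless a bundle: the double bond and the fluorine enter while the methoxy oxygen, with its hydrogen-bond acceptor, leaves, and nothing available accounts for the step or assigns it to any one of these.

Open, on these data alone, is how a directly attached 4-fluorophenyl or a 2-(4-methoxyphenyl)ethenyl would read at this position, since either would separate the contribution of the double bond from that of the ring substituent. Also open, as far as these compounds go, is how a carboxylic acid or an amine in place of the fluorine would read on the same scaffold.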